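Amino in Place of Isopropyl: Cytotoxicity Outlook

This account rests on a few compounds, and the source may have more. Where it says the series, first, only, none or still open, it means among the compounds named here.

Compound 1, `CCCc1ccc(-c2ccc3ncc(C(=O)OCC)cc3c2)cc1`: in a functional assay on RD cells (Homo sapiens) for inhibition, read by luminescence and ATP content, with a stated time of 72 h (on this read-out lower numbers stand for higher toxicity in this test and higher numbers for lower toxicity in this test), compound 1 gives > 7400 nM, a limit of the test and not a number.
Compound 2, `CCOC(=O)c1cnc2ccc(-c3ccc(C(C)C)cc3)cc2c1`: in this assay compound 2 gives > 7400 nM, likewise a limit and not a number.

Compound 2 thus stands at the limit of this assay, where both measured values sit (the limit of > 7400 nM in this assay, at which 2 of the 2 values shown sit). Among the measured compounds shown here, the one measured step, a step that the two limits leave unreadable from compound 1 to compound 2, cannot be read, since both of its ends are limits.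

Compound 3 is `CCOC(=O)c1cnc2ccc(-c3ccc(N)cc3)cc2c1`. It differs from compound 2 in one place: amino in place of isopropyl on an aromatic carbon. For the measured compounds named here, no measured step bears on this change in a readable way; the only step available is unreadable, and no other compound carries an amino group. The expectation therefore rests on where compound 2 stands, and it is expected that compound 3 again reaches the limit, which would make the step that the limit leaves unreadable from compound 2 to compound 3 unreadable in this assay. Compound 3 is estimated at 9000 nM in this assay, within a range from 2500 nM to 30000 nM, with a numbered value below the limit regarded as the less likely outcome.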

Compound 3, half-maximal cytotoxic concentration: > 7400 nM
Compound 3: a limit, no number; the forecaster's own chance of this, stated with the estimate: 70%; the middle value does not contradict the limit.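

Compound 3 also sits at a limit of the test in this assay, so neither its step from compound 1 nor its step from compound 2 can be read, as all three values are limits: the limit of > 7400 nM in this assay, at which 3 of the 3 values shown sit.

The compounds shown leave open whether propyl, isopropyl or amino makes any difference to the half-maximal cytotoxic concentration in this assay.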